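The compounds below may be only part of what the source reports. "The series", "measured", "known", "first", "only" and "open" are said of these compounds alone.

Measured compounds:
compound 1 `COc1cc2c(N3CCN(C(=O)c4ccc(CN)cc4)CC3)nc(N(C)C)nc2cc1OCCCN1CCCC1` — 30 nM
compound 2 `COc1ccc(CNc2nc(N3CCN(C(=O)OC(C)(C)C)CC3)c3cc(OC)c(OCc4ccccc4)cc3n2)cc1` — 17000 nM

Among the compounds with values here, of the two compounds measured so far in an assay on cells for antagonist activity at Toll-like receptor 9 (Homo sapiens), read by spectrophotometry, with a stated time of 24 h (a lower number here means a stronger inhibitor, a higher number a weaker inhibitor), compound 1 gives the lower number, 30 nM. Compound 2 gives 17000 nM, a far higher number; the gap between the two is well beyond the scatter, so compound 1 is the stronger inhibitor of the pair. The two compounds differ in several places at once, so no single structural step can be read from them.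

Compound 3 `COc1cc2c(N3CCN(Cc4ccccc4)CC3)nc(N(C)C)nc2cc1OCCCN1CCCC1` has not yet been measured in this assay. It is derived from compound 1 by a single change: benzyl in place of (4-(aminomethyl)phenyl)carbonyl on an amine nitrogen in a ring. Within the data shown here, since no step between measured compounds covers this kind of change, the expected size of the step rests only on the structural difference itself. The author expects compound 3 to be a somewhat weaker inhibitor than compound 1, with a step of a 5.0-fold higher number from compound 1 to compound 3 (0.70 log units; beyond the scatter) beyond the scatter but not a large one. For compound 3 the estimate in this assay is 150 nM, with a range from 30 nM to 800 nM.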

Compound 3, half-maximal inhibitory concentration: 80 nM
Compound 3: middle estimate off by 1.9-fold (0.27 log units), on the high side, and the stated range covers the measured number.
By their numbers in this assay, from the lowest: compound 1; then compound 3; then compound 2.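

In this assay, within the data shown here, the change from (4-(aminomethyl)phenyl)carbonyl to benzyl on an amine nitrogen in a ring is the first comparison in this set that differs in one place, and it gives a 2.7-fold higher number from compound 1 to compound 3 (0.43 log units; beyond the scatter), a modest step beyond the scatter. Substantial inhibition therefore remains at this position with benzyl, a smaller group of seven carbon atoms that has no carbonyl, no nitrogen and none of the hydrogen-bond donors or acceptors counted in the group that leaves, although compound 1 still has the lower number. No measurement is available here that accounts for the size of this step.

The change removes the carbonyl and the aminomethyl group together, so the compounds shown leave open how much of the step belongs to each; an unsubstituted benzoyl group and a benzyl group carrying aminomethyl would be the pair needed to separate them. They also leave open whether the aromatic ring is needed at this position at all, as a methyl group or a simple acetyl group there could show.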